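Swapping the aryl amide for a dimethyl-isoxazole amide

The source may hold more compounds than are shown below. What is called first, only, known or untested is meant among the compounds shown, and "the series" means these compounds.

Compound 3 `COc1ccc2nc(C)cc(OCC(=O)Nc3cc(C)c(F)c(C)c3)c2c1` is an aryl amide of a shared core; in a physicochemical assay for solubility, in phosphate buffer, measured as kinetic solubility, with a stated time of 1 h, at pH 7.4 (on this read-out higher numbers stand for higher solubility and lower numbers for lower solubility), compound 3 gives 31500 nM. Its companions differ only on the aryl ring: compound 1 `Cc1cc(C)cc(NC(=O)COc2cc(C)nc3ccc(F)cc23)c1` gives 28000 nM and compound 2 `COc1ccc2nc(C)cc(OCC(=O)Nc3cc(C)c(OC)c(C)c3)c2c1` gives 17000 nM, both within the scatter of compound 3. Compound 4 `COc1ccc2nc(C)cc(OCC(=O)Nc3noc(C)c3C)c2c1` changes more: 4,5-dimethyl-1,2-oxazol-3-yl in place of 4-fluoro-3,5-dimethylphenyl on an amide-type nitrogen. Among the compounds with values here, the one measured step, a 1.9-fold higher number from compound 2 to compound 3 (0.27 log units; within the scatter), concerns a single substituent on the ring that is now removed, so no measured step covers a ring exchange of this kind. With only a within-scatter step to go on, compound 4 is expected at 45000 nM, between 15000 nM and 130000 nM, a step of a 1.4-fold higher number from compound 3 to compound 4 (0.15 log units; within the scatter) that is expected to sit near the scatter.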

Compound 4, solubility: 196000 nM
Compound 4: the middle estimate sits 4.4-fold (0.64 log units) below what was measured; the whole stated range lies below it.
By their numbers in this assay, from the lowest: compounds 2, 1 and 3 (each within the scatter of the next); then compound 4.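

Within the data shown here, exchanging 4-fluoro-3,5-dimethylphenyl for 4,5-dimethyl-1,2-oxazol-3-yl on the amide-type nitrogen gives a 6.2-fold higher number from compound 3 to compound 4 (0.79 log units; beyond the scatter) in this assay and is the first change here to lie beyond the scatter. Among these compounds, the only earlier step, a 1.9-fold higher number from compound 2 to compound 3 (0.27 log units; within the scatter) for a single substituent on the aromatic ring, stayed within it. This position can therefore move the read-out when the whole ring changes.

As far as these compounds go, whether a pyridyl ring or an unsubstituted 1,2-oxazol-3-yl ring on that nitrogen would give a similar number remains open. No measurement shown accounts for the size of this step.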